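Trading a Fluorophenyl for a Vinyl Group

A few compounds are considered here, and "the series" means these few. Any claim that something is new, unique, unknown or untested is made for them only; others in the source may bear on it.

Measured so far in a functional assay on KYSE-70 cells for antiproliferative activity against KYSE-70 cell line (Homo sapiens), read by MTT assay, with a stated time of 72 h; a lower number here means a stronger inhibitor, a higher number a weaker inhibitor:
- Compound 1 `O=C(Nc1cc(F)cc(F)c1)c1cc(=O)[nH]c2cc(C(F)(F)F)ccc12`: 14200 nM
- Compound 2 `O=C(Nc1cc(F)cc(F)c1)c1cc(=O)[nH]c2cc(O)ccc12`: > 20000 nM
- Compound 3 `O=C(Nc1cccc(F)c1)c1cc(=O)[nH]c2cc(-c3cccc(F)c3)ccc12`: 12000 nM

Of the compounds shown here, three of a shared core have been measured. In this assay compound 1 gives 14200 nM. Compound 2 gives only a limit of the assay, > 20000 nM, and one of the three values therefore stands at that limit (the limit of > 20000 nM in this assay, at which 1 of the 3 values shown sits). Compound 3 gives 12000 nM, a number that sits within the usual scatter of the number for compound 1, so no order between the two can be read.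

Among the measured compounds shown here, the only measured step, an at least 1.4-fold higher number from compound 1 to compound 2 (0.14 log units; that floor lies within the scatter), touches the same position of the core but exchanges other groups, and its floor lies within the scatter.

Compound 4 `C=Cc1ccc2c(C(=O)Nc3cccc(F)c3)cc(=O)[nH]c2c1` differs from compound 3 by vinyl in place of 3-fluorophenyl on an aromatic carbon. For the measured compounds named here, no measured step covers this exchange, and the one step at this position gives no direction beyond the scatter. Compound 4 is therefore expected to give about 15000 nM, within a range from 5000 nM to 40000 nM. This expectation corresponds to a step of a 1.3-fold higher number from compound 3 to compound 4 (0.10 log units; within the scatter), which is not expected to exceed the scatter.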

Compound 4, half-maximal inhibitory concentration: 9700 nM
For compound 4 the middle estimate is 1.5-fold (0.19 log units) above the measured one; measured number inside the range.
By their numbers in this assay, from the lowest: compounds 4, 3 and 1 (each within the scatter of the next). At a limit, above all of these: compound 2.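

Exchanging the 3-fluorophenyl for vinyl on this aromatic carbon gives, in this assay, a 1.2-fold lower number from compound 3 to compound 4 (0.09 log units; within the scatter). The earlier compounds shown here offered no readable step at this position, and this pair now shows that a group with no ring and only 2 heavy atoms can stand here in place of one with 7 while the number stays within the scatter. Nothing measured here gives a cause for this result.

From the compounds shown here alone, it remains open whether the double bond of the vinyl plays any part, which an ethyl group in the same place would test. Going by these compounds, it also remains open whether an amine, a carboxylic acid or a longer chain on this carbon would move the number beyond the scatter in either direction.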